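Methoxy Added to a Saturated Lactone Core

The source may report more compounds than this note shows. Statements on the series, on what has been measured and on what is new or still open speak of the compounds shown alone.

Compound 1 `O=c1oc(CO)cc2ccccc12` and compound 2 `COc1ccc2cc(CO)oc(=O)c2c1` share one core, and compound 2 differs from compound 1 by methoxy in place of hydrogen on an aromatic carbon. In an ADME assay on HaCaT cells (Homo sapiens) for cytotoxicity, read by sulforhodamine B assay, with a stated time of 48 h (on this read-out higher numbers stand for weaker inhibition of growth and lower numbers for stronger inhibition of growth), compound 1 gives 222 ug/mL. In this assay compound 2 gives 134 ug/mL. This amounts to a 1.7-fold lower number from compound 1 to compound 2 (0.22 log units; within the scatter), so the two values cannot be told apart.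

Compound 3 `O=C1OC(CO)Cc2ccccc21` rests on a second core; how that core differs from the core of compound 1 is not broken down here. In this assay compound 3 gives only a limit of the assay, >= 250 ug/mL.

Compound 4 `COc1ccc2c(c1)C(=O)OC(CO)C2` has not yet been measured. It differs from compound 3 by methoxy in place of hydrogen on an aromatic carbon, the same change that separates compound 2 from compound 1. Two points guide the expectation: the measured step, a 1.7-fold lower number from compound 1 to compound 2 (0.22 log units; within the scatter), and (the limit of >= 250 ug/mL in this assay, at which 1 of the 3 values shown sits), where compound 3 stands. Compound 4 is therefore expected to show an at least 1.2-fold lower number from compound 3 to compound 4 (0.09 log units; that floor lies within the scatter). Compound 4 is estimated at 200 ug/mL, with a likely range from 110 ug/mL to 300 ug/mL, and a real chance that the assay again reports only a limit.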

Compound 4, concentration for 50% growth inhibition: >= 250 ug/mL
Compound 4: no number, only a limit; the forecaster's own chance of this, stated with the estimate: 50%; middle value at least 1.2-fold (0.09 log units) away from the limit.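

In this assay compound 3 and compound 4 both stand at a limit and not at a number, so no step from one to the other can be read: the limit of >= 250 ug/mL in this assay, at which 2 of the 4 values shown sit.

The compounds shown leave open how far methoxy in place of hydrogen on an aromatic carbon moves the value on the core of compound 3, if at all.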